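The compounds below may be only part of what the source reports. "The series", "measured", "known", "first", "only" and "open" are said of these compounds alone.

Compound 1 `Nc1nc(Cl)c(-c2nc3ccc(F)cc3s2)c(N[C@@H]2C[C@H](CO)[C@@H](O)[C@H]2O)n1` in an ADME assay on cells (Homo sapiens) for cytotoxicity, read by polymerase chain reaction, with a stated time of 3 days (a higher number here means that more compound is tolerated, a lower number that less compound is tolerated), reached only the limit of > 25000 nM, which is a bound of the assay and not a number. Going by the values given here, compound 2 `Cc1nc(NC(C)C)nc(N[C@@H]2C[C@H](CO)[C@@H](O)[C@H]2O)c1-c1nc2ccccc2s1` is the one compound with a measured value in this assay, giving 13000 nM. Compound 3 `Cc1nc(NCc2ccccn2)nc(N[C@@H]2C[C@H](CO)[C@@H](O)[C@H]2O)c1-c1nc2ccccc2s1` differs from compound 2 by (pyridin-2-yl)methyl in place of isopropyl on a nitrogen on an aromatic ring. Among the compounds with values here, no measured pair shows what this change does, so the step of no change at the digits printed from compound 2 to compound 3 (within the scatter) is expected to stay within the usual scatter, in no set direction. Compound 3 is therefore estimated at 13000 nM, with a range from 5000 nM to 30000 nM.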

Compound 3, half-maximal cytotoxic concentration: 13000 nM
The estimate for compound 3 equals the measured number at the digits printed, within the range that was stated.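

In this assay, going by these compounds alone, the first measured pair at this position gives no change at the digits printed from compound 2 to compound 3 (within the scatter). Replacing isopropyl with (pyridin-2-yl)methyl on this nitrogen brings in a six-membered aromatic ring, and the reading stays within the scatter. Nothing given here bears on the cause of this result.

On these data alone, what a benzyl group, with carbon in place of the ring nitrogen, would give at this position stays open. So does the outcome for a carboxylic acid or a longer chain on this nitrogen.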